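The source may hold more compounds than are shown below. What is called first, only, known or untested is meant among the compounds shown, and "the series" means these compounds.

Measured compounds:
Compound 1 `CSCC[C@H](NC(=O)c1ccc(NCc2cncn2Cc2cccc(Cl)c2)cc1-c1ccccc1)C(=O)O` — in a functional assay on NIH3T3 cells (Mus musculus) (a higher number here means that more compound is needed for the effect, a lower number that less compound is needed), compound 1 gives only the limit > 10 uM.
Compound 2 `CSCC[C@H](NC(=O)c1ccc(NCc2cncn2Cc2ccc([N+](=O)[O-])cc2)cc1-c1ccccc1)C(=O)O` — in this assay compound 2 gives only the limit > 10 uM.

Compound 2 thus stands at the assay limit, not at a number. Among the measured compounds shown here, the only measured step, a step that the two limits leave unreadable from compound 1 to compound 2, cannot be read because the limit of > 10 uM in this assay, at which 2 of the 2 values shown sit, leaves both ends of it open. Compound 3 `CSCC[C@H](NC(=O)c1ccc(NCc2cncn2Cc2cccc(C#N)c2)cc1-c1ccccc1)C(=O)O` has not been measured. It differs from compound 2 by 3-cyanophenyl in place of 4-nitrophenyl on a saturated chain carbon bound to an aromatic nitrogen. For the measured compounds named here, the one step recorded, from compound 1 to compound 2, also exchanges the group on that chain carbon and gives no readable size, so no direction can be taken from it. The expectation for compound 3 is therefore that the step that the limit leaves unreadable from compound 2 to compound 3 stays within the scatter. Compound 3 is estimated in this assay at 20 uM, in the range 5 uM to 80 uM, most probably again reported as a limit.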

Compound 3, concentration for half-maximal effect: > 10 uM
Compound 3 ended at the assay's limit; the forecaster's own chance of this, stated with the estimate: 85%; the middle value does not contradict the limit.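

In this assay compound 3 gives only the limit > 10 uM. Among the compounds shown here, no step among compound 1, compound 2 and compound 3 can be read: the limit of > 10 uM in this assay, at which 3 of the 3 values shown sit. The compounds shown leave open where each of the three truly lies and whether exchanging the group on the saturated chain carbon changes the effect at all.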